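Changing the Ring Group on the Carbonyl Carbon

The source may hold more compounds than are shown below. What is called first, only, known or untested is meant among the compounds shown, and "the series" means these compounds.

Three compounds share one core and differ only in the group attached to a carbonyl carbon. Compound 1 `Cc1nc(S(C)(=O)=O)ccc1Oc1ncnc(OC2CCN(C(=O)SC3CCC3)CC2)c1F` carries a four-membered non-aromatic ring of carbon bearing sulfur, and in a functional assay on isolated protein for inhibition of Glucose-dependent insulinotropic receptor (Rattus norvegicus), read by HTRF and cAMP accumulation (on this read-out higher numbers stand for larger maximal responses and lower numbers for smaller maximal responses), compound 1 gives 81%. Compound 2 `Cc1nc(S(C)(=O)=O)ccc1Oc1ncnc(OC2CCN(C(=O)C3(F)CCC3)CC2)c1F` carries the same ring bearing fluorine instead, and compound 2 gives 91%; the step of a number 10 percentage points higher from compound 1 to compound 2 (within the scatter). Compound 3 `Cc1nc(S(C)(=O)=O)ccc1Oc1ncnc(OC2CCN(C(=O)c3noc(C(C)(C)F)n3)CC2)c1F` carries a five-membered aromatic ring with 3 hetero atoms, and compound 3 gives 74%, the lowest of the three numbers; the step of a number 7 percentage points lower from compound 1 to compound 3 (within the scatter), while the step of a number 17 percentage points lower from compound 2 to compound 3 (beyond the scatter).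

Compound 4 `Cc1nc(S(C)(=O)=O)ccc1Oc1ncnc(OC2CCN(C(=O)c3ncc(Cl)cn3)CC2)c1F` is reached from compound 3 by the change (a group of 7 heavy atoms (4 carbon, 2 nitrogen, 1 chlorine; one six-membered aromatic ring with 2 hetero atoms) in place of a group of 9 heavy atoms (5 carbon, 2 nitrogen, 1 oxygen, 1 fluorine; one five-membered aromatic ring with 3 hetero atoms), on a carbonyl carbon). The steps from compound 1 and from compound 2 to compound 3 show that exchanging the group on this carbonyl carbon moves the maximal response only modestly, and neither involves a six-membered aromatic ring, so the direction is uncertain. A small move back toward the other two compounds is expected, a number 6 percentage points higher from compound 3 to compound 4 (within the scatter), giving for compound 4 an estimated 80% within 65% to 95%.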

Compound 4, largest response reached (reported as efficacy), in percent of the reference or control that the assay uses: 77%
Compound 4: the middle estimate sits 3 percentage points above what was measured; measured number inside the range.
By their numbers in this assay, from the lowest: compounds 3, 4, 1 and 2 (each within the scatter of the next, the first and the last beyond it).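

In this assay, a six-membered aromatic ring on this carbonyl carbon, the 5-chloropyrimidin-2-yl group, cannot be told apart from the five-membered aromatic ring or the cyclobutylsulfanyl group, as a number 3 percentage points higher from compound 3 to compound 4 (within the scatter) and a number 4 percentage points lower from compound 1 to compound 4 (within the scatter) both show. The four-membered ring bearing fluorine still stands apart, with a number 14 percentage points lower from compound 2 to compound 4 (beyond the scatter) matching what compound 3 showed, so two different aromatic rings now sit beyond the scatter from that ring while neither does from compound 1. No measurement here explains this difference.

As far as these compounds go, what a pyrimidin-2-yl ring with a methoxy group in place of the chlorine would give on this carbonyl carbon stays open. So does the effect of a plain phenyl ring or an open chain such as tert-butyl at the same place.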